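This account rests on a few compounds, and the source may have more. Where it says the series, first, only, none or still open, it means among the compounds named here.

Working notes on the cytotoxicity series. Compound 1 `O=C(/C=C/c1ccc(N2CCCCC2)cc1)c1cccs1` is measured in an ADME assay on Vero cells (Chlorocebus sabaeus) for cytotoxicity, with a stated time of 5 days (on this read-out lower numbers stand for stronger inhibition and higher numbers for weaker inhibition), where compound 1 gives 65500 nM. Compound 2 `c1cc(C2=NNC(c3ccc(N4CCCCC4)cc3)C2)cs1` gives in this assay a value of 29500 nM. Of the two numbers in hand, compound 2 stands lowest, and the gap to compound 1 lies beyond the usual scatter, so the two values are distinguishable. Within the data shown here, no comparison between measured compounds that differ in a single place is available in this set.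

The next compound is compound 3 `Clc1cc(C2=NNC(c3ccc(N4CCCCC4)cc3)C2)c(Cl)s1`, which differs from compound 2 by 2,5-dichlorothiophen-3-yl in place of thiophen-3-yl on a carbon with a double bond to nitrogen. Among the measured compounds shown here, with no measured step of this kind to draw on, the expectation for compound 3 in this assay is a step downward that is moderate, at or a little past the edge of the scatter, expressed as a 2.0-fold lower number from compound 2 to compound 3 (0.29 log units; within the scatter). The estimated value for compound 3 in this assay is 15000 nM, with a range from 5000 nM to 45000 nM.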

Compound 3, half-maximal inhibitory concentration: 53900 nM
Beside the measured number, compound 3's estimate is 3.6-fold (0.56 log units) below it, and the stated range ends below it.
By their numbers in this assay, from the lowest: compounds 2, 3 and 1 (each within the scatter of the next, the first and the last beyond it).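

Among these compounds, the step is the first comparison between compounds that differ in a single place: 2,5-dichlorothiophen-3-yl in place of thiophen-3-yl gives a 1.8-fold higher number from compound 2 to compound 3 (0.26 log units; within the scatter) in this assay. On a carbon with a double bond to nitrogen, the chlorine-bearing group is therefore accommodated without a separation between the two compounds on this read-out. This single pair cannot show how other groups at this position would behave. No supporting measurement bears on this outcome, so it remains an observation without an assigned cause.

The compounds shown leave open how each chlorine contributes alone, since neither 2-chlorothiophen-3-yl nor 5-chlorothiophen-3-yl appears among them. Also open, from the compounds shown here alone, is whether a methyl group, an amine or a carboxylic acid on the thiophen-3-yl would separate from compound 2 in this assay.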